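Phenyl added at the oxygen-bound carbon of compound 3

The source may report more compounds than this note shows. Statements on the series, on what has been measured and on what is new or still open speak of the compounds shown alone.

Compound 1 `C=CC[n+]1cn(C)c2nc[nH]/c(=N\OC)c21` is the smallest member of the set. In a functional assay on CEM/s cells (Homo sapiens) for cytotoxicity (on this read-out lower numbers stand for stronger inhibition and higher numbers for weaker inhibition), compound 1 gives > 80000 nM, which is a limit of the assay and not a number. Compound 2 `CO/N=c1\[nH]cnc2c1[n+](C/C=C(\C)CC/C=C(\C)CC/C=C(\C)CCC=C(C)C)cn2Cc1ccccc1` carries a long unsaturated chain on the shared core; in this assay compound 2 gives 2240 nM. Compound 3 `CO/N=c1\[nH]cnc2c1[n+](C/C=C(\C)CC/C=C(\C)CC/C=C(\C)CCC=C(C)C)cn2C(c1ccccc1)c1ccccc1` gives 3540 nM in this assay. Of the two numbers shown, compound 3 has the higher one, yet the step of a 1.6-fold higher number from compound 2 to compound 3 (0.20 log units; within the scatter) lies within the scatter, so the two compounds stand level. Compound 4 `CC(C)=CCC/C(C)=C/CC/C(C)=C/CC/C(C)=C/C[n+]1cn(C(c2ccccc2)c2ccccc2)c2nc[nH]/c(=N\OCc3ccccc3)c21` differs from compound 3 by phenyl in place of hydrogen on a saturated chain carbon bound to an oxygen. For the measured compounds named here, no measured step touches this place; the only measured step, a 1.6-fold higher number from compound 2 to compound 3 (0.20 log units; within the scatter), adds a phenyl at a different carbon and gave no change beyond the scatter. For compound 4 the expected step is therefore a 1.0-fold lower number from compound 3 to compound 4 (0.00 log units; within the scatter), nothing beyond the scatter in either direction. Compound 4 is accordingly estimated at 3500 nM in this assay, with a range from 1200 nM to 10000 nM.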

Compound 4, half-maximal inhibitory concentration: 9110 nM
Beside the measured number, compound 4's estimate is 2.6-fold (0.42 log units) below it; the range from low to high includes it.
By their numbers in this assay, from the lowest: compounds 2 and 3 (each within the scatter of the next); then compound 4. At a limit, above all of these: compound 1.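

In this assay, for the compounds shown here, the change from methoxy to benzyloxy gives a 2.6-fold higher number from compound 3 to compound 4 (0.41 log units; beyond the scatter), the first step in the set to lie beyond the scatter. The earlier phenyl addition, on a saturated chain carbon bound to an aromatic carbon and an aromatic nitrogen, gave a 1.6-fold higher number from compound 2 to compound 3 (0.20 log units; within the scatter), so the same group did not act alike at the two places. On the saturated chain carbon bound to an oxygen, adding phenyl modestly raises the number, though this rests on a single pair of compounds.

Nothing measured here accounts for this step. Going by these compounds, whether ethoxy, a longer chain on the oxygen, or a benzyloxy group whose ring carries an amine would raise the number in this assay in the same way stays open.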